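Aryl group on the saturated ring carbon: paw edema inhibition

A few compounds are considered here, and "the series" means these few. Any claim that something is new, unique, unknown or untested is made for them only; others in the source may bear on it.

Measured so far:
compound 1 `O=C1N=C(C2C(=O)c3ccccc3C2=O)CC(c2ccccc2[N+](=O)[O-])N1` gives 11% in a functional assay on the whole organism for inhibition, with Rattus norvegicus as the target, read by paw edema, with stated times of 30 min and 1 h, at a dose of 10 mg/kg by the oral route; a lower number here means less inhibition, a higher number more inhibition at the dose given (going by the name of the read-out)
compound 2 `CN(C)c1ccc(C2CC(C3C(=O)c4ccccc4C3=O)=NC(=O)N2)cc1` gives 15% in this assay

Compound 2 stands at the upper end of the two numbers shown, with compound 1 nearest, but the step of a number 4 percentage points higher from compound 1 to compound 2 (within the scatter) lies within the scatter, so the two compounds are not separated by the read-out.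

Compound 3 `O=C1N=C(C2C(=O)c3ccccc3C2=O)CC(c2ccccc2O)N1` has not yet been measured. Its change from compound 2 is 2-hydroxyphenyl in place of 4-(dimethylamino)phenyl on a saturated ring carbon

Going by the values given here, the only measured step that bears on this change is the one at the same saturated ring carbon, from compound 1 to compound 2, where the aryl group was exchanged and the read-out moved by a number 4 percentage points higher from compound 1 to compound 2 (within the scatter), within the scatter. On that single step a further exchange of the aryl group at this carbon is not expected to move the number beyond the scatter; the step from compound 2 to compound 3 is estimated at a number 2 percentage points lower from compound 2 to compound 3 (within the scatter).

Compound 3 is therefore expected to give about 13% in this assay, within a range from 3% to 25%.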

Compound 3, a percentage reported as inhibition, in the whole organism at one dose (the size of the read-out at that dose, not a potency): 24%
The estimate for compound 3 lay 11 percentage points below the measured number; measured number inside the range.
By their numbers in this assay, from the lowest: compounds 1, 2 and 3 (each within the scatter of the next, the first and the last beyond it).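

In this assay, the aryl group on the saturated ring carbon now gives its first step beyond the scatter, with hydroxy in place of nitro on an aromatic carbon (a number 13 percentage points higher from compound 1 to compound 3 (beyond the scatter)), so a change at this position can register in the read-out, though the step is modest. Going by these compounds alone, the exchange of 4-(dimethylamino)phenyl for 2-hydroxyphenyl (a number 9 percentage points higher from compound 2 to compound 3 (within the scatter)) stays within the scatter, so compound 2 is not separated from compound 3 or from compound 1, and only the pair with 2-nitrophenyl and 2-hydroxyphenyl is told apart. Nothing at hand accounts for the step between those two groups.

Still open, going by these compounds, is whether that step depends on the hydroxy group itself or only on the absence of the nitro group, a question on which a 2-methoxyphenyl or 2-aminophenyl group at the same carbon would bear. All three numbers also come from a single oral dose, so they show the size of the read-out at that dose and leave open how the compounds would compare as the dose changes.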